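The source may hold more compounds than are shown below. What is called first, only, known or untested is meant among the compounds shown, and "the series" means these compounds.

Measured so far:
compound 1 `COc1ccc(F)cc1N1C(=O)CSC1c1cccc(C(=O)NCCCCn2cccn2)c1`: 480 mL.min-1.g-1
compound 2 `COc1ccc(F)cc1N1C(=O)CSC1c1cccc(C(=O)NCCCCc2ccccc2)c1`: 1650 mL.min-1.g-1

In an ADME assay on microsomes from liver (Canis lupus familiaris) for metabolic stability, read by LC-MS, using NADPH, with a stated time of 10 min, tested at 0.1 uM (a higher number here means faster removal of the compound, a lower number slower removal), compound 1 gives 480 mL.min-1.g-1, the lowest of the two numbers. Compound 2 gives 1650 mL.min-1.g-1. For the measured compounds named here, the only measured step, a 3.4-fold higher number from compound 1 to compound 2 (0.54 log units; beyond the scatter), concerns a saturated chain carbon four bonds along the chain from an amide-type nitrogen, not the ring. Going by the values given here, compound 3 `O=C(NCCCCn1cccn1)c1cccc(C2SCC(=O)N2c2cc(F)ccn2)c1` differs from compound 1 on an amide-type nitrogen in a ring: 4-fluoropyridin-2-yl in place of 5-fluoro-2-methoxyphenyl on an amide-type nitrogen in a ring No measured step bears on this change, so no step beyond the scatter is expected in this assay; the expected step is a 1.1-fold lower number from compound 1 to compound 3 (0.06 log units; within the scatter). Compound 3 is therefore estimated at 420 mL.min-1.g-1, with a range from 150 mL.min-1.g-1 to 1100 mL.min-1.g-1.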

Compound 3, intrinsic clearance in microsomes: 68.2 mL.min-1.g-1
For compound 3 the middle estimate is 6.2-fold (0.79 log units) above the measured one; the whole stated range lies above it.
By their numbers in this assay, from the lowest: compound 3; then compound 1; then compound 2.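

In this assay, the group on the amide-type nitrogen in a ring proves to be a second place where the number moves, not only the far end of the chain: there is a 7.0-fold lower number from compound 1 to compound 3 (0.85 log units; beyond the scatter) with 4-fluoropyridin-2-yl in place of 5-fluoro-2-methoxyphenyl. Nothing available explains this drop. Going by these compounds, the change swaps the ring, removes the methoxy group and alters the fluorine's place at once, so their separate shares stay open; a plain phenyl or a 5-fluoropyridin-2-yl group would divide them. On these data alone, whether 4-fluoropyridin-2-yl lowers the number equally with the phenyl chain end of compound 2 also remains open.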